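Adding 3-hydroxypropyl to compound 3

The source may hold more compounds than are shown below. What is called first, only, known or untested is meant among the compounds shown, and "the series" means these compounds.

In an ADME assay on MRC5 cells (Homo sapiens) for cytotoxicity, read by fluorescence and resazurin assay, with a stated time of 3 days (a higher number here means that more compound is needed for the effect, a lower number that less compound is needed), compound 1 `COc1ccc(Cn2cc(C3(O)C=CC(=O)C=C3)nn2)cc1` gives 450 nM, compound 2 `O=C1C=CC(O)(c2cc3ccc(F)cc3n2S(=O)(=O)c2ccccc2)C=C1` gives 170 nM and compound 3 `O=C1C=CC(O)(c2cc3ccccc3n2S(=O)(=O)c2ccccc2)C=C1` gives 110 nM. Compound 3 lies within the scatter of compound 2 and beyond the scatter under compound 1.

Still unmeasured is compound 4 `O=C1C=CC(O)(c2cc3ccccc3n2S(=O)(=O)c2ccc(CCCO)cc2)C=C1`, which differs from compound 3 in one place: 3-hydroxypropyl in place of hydrogen on an aromatic carbon. Here 3-hydroxypropyl stands in place of hydrogen on an aromatic carbon, para to a large group, so that phenyl becomes 4-(3-hydroxypropyl)phenyl.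

Going by the values given here, only one measured step bears on this: a 1.5-fold lower number from compound 2 to compound 3 (0.19 log units; within the scatter), with hydrogen in place of fluoro on an aromatic carbon. That step lies elsewhere in the molecule and replaces a single atom, so its guidance is indirect. Among the compounds with values here, no measured compound varies the phenyl that changes here, and none carries this chain.

The expectation therefore rests on compound 3 at 110 nM in this assay. The expected change is a 1.2-fold higher number from compound 3 to compound 4 (0.07 log units; within the scatter), which means no step beyond the scatter in either direction. Compound 4 is estimated at 130 nM, with an expected range of 55 nM to 300 nM.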

Compound 4, half-maximal effective concentration: 51 nM
The estimate for compound 4 lay 2.5-fold (0.41 log units) above the measured number; measured number below the stated range.
By their numbers in this assay, from the lowest: compound 4; then compounds 3 and 2 (each within the scatter of the next); then compound 1.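

In this assay, going by these compounds alone, the phenyl that becomes 4-(3-hydroxypropyl)phenyl proves to be a place where a change moves the number (a 2.2-fold lower number from compound 3 to compound 4 (0.33 log units; beyond the scatter)), whereas the only earlier step, on a single atom elsewhere in the molecule, did not move it beyond the scatter (a 1.5-fold lower number from compound 2 to compound 3 (0.19 log units; within the scatter)). The direction matters for this readout: adding the 3-hydroxypropyl chain at this place does not lessen cytotoxicity in these cells, and less compound is needed for the effect, although the step is modest and rests on a single pair. Nothing at hand accounts for this step.

On these data alone, it remains open whether the step belongs to the terminal hydroxyl or to the carbon chain itself, a question that a plain propyl, a longer chain ending in hydroxyl, a terminal amine or a carboxylic acid at the same place would address. Within the data shown here, it is also open whether 3-hydroxypropyl at this place would give a step of similar size and direction on the fluoro-bearing compound 2, since the series so far holds this chain on the core of compound 3 alone.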